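Aryl swap and loss of the ether oxygen

A few compounds are considered here, and "the series" means these few. Any claim that something is new, unique, unknown or untested is made for them only; others in the source may bear on it.

Compound 1 `Cc1ccc(C)c(OCc2nnc(C(=O)Nc3ccc(CCC(=O)O)cc3)s2)c1` is the reference point of this pair. In a functional assay on CHO cells for agonist activity at Free fatty acid receptor 1 (Homo sapiens), read by FLIPR and calcium flux, tested at 1 uM (a lower number here means that less compound is needed, a higher number that more compound is needed for the effect), compound 1 gives 1530 nM. Going by the values given here, the only other number on hand, that of compound 2 `CCc1ccc(OCc2nnc(C(=O)Nc3ccc(CCC(=O)O)cc3)s2)cc1` at 1170 nM, is not separated from it beyond the scatter: the step of a 1.3-fold lower number from compound 1 to compound 2 (0.12 log units; within the scatter) amounts to no more than replacing one aryl on the oxygen by another with no measurable consequence.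

Compound 3 `O=C(O)CCc1ccc(NC(=O)c2nnc(Cc3ccc(Cl)cc3)s2)cc1` is not yet measured. Its difference from compound 1 is 4-chlorophenyl in place of 2,5-dimethylphenoxy on a saturated chain carbon bound to an aromatic carbon. Among the compounds with values here, this change goes further than the measured step, since the oxygen is lost together with the aryl; no measured pair covers that part, so the only bearing evidence is the flat step from compound 1 to compound 2, which argues that the aryl itself is not decisive here.

The expectation for compound 3 in this assay is therefore a number close to that of compound 1, with the uncertainty widened for the untested loss of the oxygen, an estimated step of a 1.0-fold lower number from compound 1 to compound 3 (0.01 log units; within the scatter). The estimate for compound 3 is 1500 nM, within a range from 500 nM to 4500 nM.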

Compound 3, half-maximal effective concentration: 2390 nM
Compound 3: the middle estimate sits 1.6-fold (0.20 log units) below what was measured; the range from low to high includes it.
By their numbers in this assay, from the lowest: compounds 2, 1 and 3 (each within the scatter of the next, the first and the last beyond it).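

Going by these compounds alone, compound 3 brings the first evidence on removing the oxygen at this position. In this assay, the 4-chlorophenyl in place of 2,5-dimethylphenoxy on a saturated chain carbon bound to an aromatic carbon stays within the scatter (a 1.6-fold higher number from compound 1 to compound 3 (0.19 log units; within the scatter)), whereas the replacement of 4-ethylphenoxy at the same place gives a modest step beyond it (a 2.0-fold higher number from compound 2 to compound 3 (0.31 log units; beyond the scatter)). The reading of this change therefore depends on the group it replaces, and no measurement on hand gives a reason for that difference.

The compounds shown leave open how much of the modest step belongs to the oxygen and how much to the aryl, as both change together in compound 3. A 4-chlorophenoxy group at this place and a 4-ethylphenyl group directly on the same saturated chain carbon would separate the two parts, and an amine nitrogen in place of the ether oxygen would test whether any linking atom at this point matters at all.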